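Working notes: from compound 2 to compound 4

The source may report more compounds than this note shows. Statements on the series, on what has been measured and on what is new or still open speak of the compounds shown alone.

Measured in a functional assay on CAL-27 cells (Homo sapiens) for antiproliferative activity, read by MTT assay, with a stated time of 72 h; on this read-out higher numbers stand for weaker inhibition and lower numbers for stronger inhibition:
- compound 1 `CCNC(=O)NOCc1ccc(/C=C/C(=O)NO)cc1`: 14000 nM
- compound 2 `O=C(/C=C/c1ccc(CONC(=O)Nc2ccccc2)cc1)NO`: 62000 nM
- compound 3 `Cc1cc(C)c(NC(=O)NOCc2ccc(/C=C/C(=O)NO)cc2)c(C)c1`: 3490 nM

Compound 2 carries the highest number of the three. Compound 4 `O=C(/C=C/c1ccc(CONC(=O)Nc2ccccc2-c2ccccc2)cc1)NO` differs from it by phenyl in place of hydrogen on an aromatic carbon. Within the data shown here, two measured steps bear on this change. The closest is an 18-fold lower number from compound 2 to compound 3 (1.25 log units; beyond the scatter), which is large and also adds to the phenyl group. The other is a 4.4-fold higher number from compound 1 to compound 2 (0.65 log units; beyond the scatter), which is modest. Among the measured compounds shown here, no measured compound carries a phenyl substituent of this kind, so the precedent is indirect. A modest to large step toward a lower number is therefore expected in this assay. The expected change is a 4.1-fold lower number from compound 2 to compound 4 (0.62 log units; beyond the scatter). Compound 4 is estimated at 15000 nM, with an expected range of 4000 nM to 55000 nM.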

Compound 4, half-maximal inhibitory concentration: 2620 nM
The estimate for compound 4 lay 5.7-fold (0.76 log units) above the measured number, outside the stated range (below it).
By their numbers in this assay, from the lowest: compounds 4 and 3 (each within the scatter of the next); then compound 1; then compound 2.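

In this assay, phenyl in place of hydrogen on an aromatic carbon, ortho to a large group, gives a 24-fold lower number from compound 2 to compound 4 (1.37 log units; beyond the scatter). The earlier compounds shown here showed a large step down from compound 2 only with the 2,4,6-trimethylphenyl group; this result shows that one added phenyl on that aromatic ring also gives a large step. Nothing available accounts for the size of this step.

Open, as far as these compounds go, is whether a methoxy group, an amine or a carboxylic acid on the same aromatic carbon would give a step of similar size.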